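Ring closure at the chain end of compound 1

The source may report more compounds than this note shows. Statements on the series, on what has been measured and on what is new or still open speak of the compounds shown alone.

Compound 1, with the structure `CCN(CC)CCCOc1cc2ncnc(Nc3nc4ccc(C(=O)Nc5c(C)cccc5C)cc4s3)c2cc1OC`, was tested in a functional assay on A549 cells (Homo sapiens) for cytotoxicity, read by WST assay, with a stated time of 72 h; a lower number here means a stronger inhibitor, a higher number a weaker inhibitor. In this assay compound 1 gave only the limit > 100000 nM, a boundary of the measurement rather than a number. Two other compounds from the same series, compound 2 `COc1cc2c(Nc3nc4ccc(C(=O)Nc5c(C)cccc5Cl)cc4s3)ncnc2cc1OCCCN1CCC(C)CC1` and compound 3 `COc1cc2c(Nc3nc4ccc(C(=O)Nc5c(C)cc(C)cc5C)cc4s3)ncnc2cc1OCCCN1CCCCC1C`, were measured as well: compound 2 gave 9700 nM in this assay, and compound 3 gave 5800 nM, two values that lie within the usual scatter of each other. Both differ from compound 1 in more than one place, so no single step can be read from them.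

Compound 4, with the structure `COc1cc2c(Nc3nc4ccc(C(=O)Nc5c(C)cccc5C)cc4s3)ncnc2cc1OCCCN1CCCC1`, has not yet been measured. The change from compound 1 to compound 4 is pyrrolidin-1-yl in place of diethylamino on a saturated chain carbon, three bonds along the chain from an oxygen on an aromatic ring. Since compound 1 sits at the limit shown as the limit of > 100000 nM in this assay, at which 1 of the 3 values shown sits, the size of the step cannot be fixed from the numbers in hand. Compound 4 is expected to land near 50000 nM, with a range from 10000 nM to 200000 nM, which would mean an estimated step of an at least 2.0-fold lower number from compound 1 to compound 4 (0.30 log units; that floor lies within the scatter).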

Compound 4, half-maximal inhibitory concentration: 83800 nM
Compound 4: middle estimate off by 1.7-fold (0.22 log units), on the low side, within the range that was stated.
By their numbers in this assay, from the lowest: compounds 3 and 2 (each within the scatter of the next); then compound 4. At a limit, above all of these: compound 1.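

In this assay compound 1 gives only a limit, > 100000 nM. Tying the chain-end amine into a ring keeps the same count of five heavy atoms and adds one five-membered ring, and this change gives the series a first readable step at this position: an at least 1.1-fold lower number from compound 1 to compound 4 (0.07 log units; that floor lies within the scatter). That figure is only a floor, so the change may do no more than the usual scatter or may do much more, because one end of the step is a limit: the limit of > 100000 nM in this assay, at which 1 of the 4 values shown sits.

Within the data shown here, compounds 2 and 3 differ from compound 4 in more than one place, so no steps to them can be read. From the compounds shown here alone, on this same core, it stays open how a morpholin-4-yl or dimethylamino group at the chain end, or a longer chain carrying the pyrrolidin-1-yl group, would read.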